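The compounds below may be only part of what the source reports. "The series", "measured", "known", "first", "only" and "open" are said of these compounds alone.

Compound 1 `CCCCCCCCCCn1cc(/C=C/C(=O)c2ccc(NC(=O)CN3CCN(c4ccccc4)CC3)cc2)nn1`, 39500 nM in a functional assay on SK-N-SH cells (Homo sapiens) for inhibition, read by MTT assay; a lower number here means a stronger inhibitor, a higher number a weaker inhibitor; compound 2 `CCCCCCCCn1cc(/C=C/C(=O)c2ccc(NC(=O)CN3CCN(C(=O)OC(C)(C)C)CC3)cc2)nn1`, 38000 nM; compound 3 `CCCCCCCCn1cc(/C=C/C(=O)c2ccc(NC(=O)CN3CCN(c4ccc([N+](=O)[O-])cc4)CC3)cc2)nn1`, 51400 nM.

All three numbers lie within the usual scatter of one another, so compound 2 is not separated from compound 1 or compound 3 beyond the scatter. Compound 4 `CCCCCCCCCCn1cc(/C=C/C(=O)c2ccc(NC(=O)CN3CCN(C(=O)OC(C)(C)C)CC3)cc2)nn1` differs from compound 2 by ethyl in place of hydrogen on a saturated chain carbon, eight bonds along the chain from an aromatic nitrogen. Going by the values given here, no measured pair isolates this chain change: compound 1 carries the longer chain but also differs at the ring nitrogen, and its number sits close to that of compound 2. Among the compounds with values here, the one single-point step known, a 1.4-fold higher number from compound 2 to compound 3 (0.13 log units; within the scatter), stayed within the scatter. Compound 4 is therefore expected to show no change beyond the scatter, a step of no change at the digits printed from compound 2 to compound 4 (within the scatter), giving an estimate of 38000 nM, between 19000 nM and 76000 nM.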

Compound 4, half-maximal inhibitory concentration: 77800 nM
Beside the measured number, compound 4's estimate is 2.0-fold (0.31 log units) below it; the measured number lies above the stated range.
By their numbers in this assay, from the lowest: compounds 2, 1, 3 and 4 (each within the scatter of the next, the first and the last beyond it).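

In this assay, going by these compounds alone, ethyl in place of hydrogen on this saturated chain carbon gives the only step so far beyond the scatter (a 2.0-fold higher number from compound 2 to compound 4 (0.31 log units; beyond the scatter)), so this chain position responds to the change, though modestly. Tert-butoxycarbonyl in place of phenyl on the ring amine nitrogen stays within the scatter (a 2.0-fold higher number from compound 1 to compound 4 (0.29 log units; within the scatter)). Nothing available explains the chain step. From the compounds shown here alone, whether a dodecyl chain or a hexyl chain would continue this trend remains open. So does whether the same chain change would have this effect with phenyl or 4-nitrophenyl on that nitrogen.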